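The compounds below may be only part of what the source reports. "The series", "measured", "known", "first", "only" and "open" are said of these compounds alone.

Compounds measured in a functional assay on CHO cells for agonist activity at Free fatty acid receptor 1 (Homo sapiens), read by calcium flux; on this read-out lower numbers stand for an effect already at smaller amounts and higher numbers for an effect only at larger amounts of compound:
compound 1, `O=C(O)CCc1ccc(OCc2nnc(C(=O)Nc3ccccc3)s2)cc1`, 1060 nM;
compound 2, `COc1ccc(NC(=O)c2nnc(COc3ccc(CCC(=O)O)cc3)s2)cc1`, only a limit, > 10000 nM;
compound 3, `Cc1cccc(NC(=O)c2nnc(COc3ccc(CCC(=O)O)cc3)s2)c1`, 1770 nM.

Among the two numbers given, compound 3 carries the highest; its nearest neighbour is compound 1, and the step from compound 1 to compound 3 is a 1.7-fold higher number from compound 1 to compound 3 (0.22 log units; within the scatter), so the two cannot be ordered. The value of compound 2 is a limit of this assay, not a number, as the line the limit of > 10000 nM in this assay, at which 1 of the 3 values shown sits, records.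

Compound 4, `O=C(O)CCc1ccc(OCc2nnc(C(=O)Nc3ccc(F)cc3)s2)cc1`, has not been measured. It differs from compound 3 by 4-fluorophenyl in place of 3-methylphenyl on an amide-type nitrogen. For the measured compounds named here, two measured steps bear on it. The step from compound 1 to compound 2, an at least 9.4-fold higher number from compound 1 to compound 2 (0.97 log units; beyond the scatter), shows that a 4-methoxyphenyl on the amide-type nitrogen removes the effect from the measurable range, and the step from compound 2 to compound 3, an at least 5.6-fold lower number from compound 2 to compound 3 (0.75 log units; beyond the scatter), shows the 3-methylphenyl restoring it. Going by the values given here, the 4-fluorophenyl is a different group from either, so no step of comparable kind exists. Compound 4 is therefore expected to sit near compound 3, and the estimated step from compound 3 to compound 4 is a 1.0-fold higher number from compound 3 to compound 4 (0.01 log units; within the scatter), within the scatter. The estimate for compound 4 in this assay is 1800 nM, with a range from 700 nM to 5000 nM.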

Compound 4, half-maximal effective concentration: 6640 nM
Beside the measured number, compound 4's estimate is 3.7-fold (0.57 log units) below it; measured number outside the range, above it.
By their numbers in this assay, from the lowest: compounds 1 and 3 (each within the scatter of the next); then compound 4. At a limit, above all of these: compound 2.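

In this assay, 4-fluorophenyl in place of 3-methylphenyl on an amide-type nitrogen gives a 3.8-fold higher number from compound 3 to compound 4 (0.57 log units; beyond the scatter). For the compounds shown here, the fluoro, set against the hydrogen it replaces, also gives a step beyond the scatter, a 6.3-fold higher number from compound 1 to compound 4 (0.80 log units; beyond the scatter), whereas the methyl of compound 3 had left no step that could be told from the scatter, so this is the first measured number on the series to separate from that of compound 1. The value of compound 2 is a limit of the assay, not a number. That limit allows only an at least 1.5-fold lower number from compound 2 to compound 4 (0.17 log units; that floor lies within the scatter).

The compounds shown give no cause for these steps. On these data alone, how a nitrile or an amine in place of the fluoro on the aromatic carbon would read in this assay remains open.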